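The source may hold more compounds than are shown below. What is called first, only, known or untested is meant among the compounds shown, and "the series" means these compounds.

Measured compounds:
compound 1 `NC1=NC2(CCSCC2)N(OCCCOc2cccc(Cl)c2)C(N)=N1`, 88.8%
compound 2 `NC1=NC2(CCOCC2)N(OCCCOc2ccc(Cl)c(Cl)c2)C(N)=N1`, "not determined" (no result reported) in an assay on isolated protein for inhibition of Dihydrofolate reductase (Homo sapiens), read by spectrophotometry, using NADPH, with stated times of 5 s and 6 min, tested at 50 uM; on this read-out higher numbers stand for a stronger effect at the one concentration tested and lower numbers for a weaker effect
compound 3 `NC1=NC2(CCSCC2)N(OCCCOc2cccc(Cl)c2Cl)C(N)=N1`, 89.8%

In this assay compound 1 gives 88.8% and compound 3 gives 89.8%; both carry the thioether-bearing core. The step of a number 1 percentage points higher from compound 1 to compound 3 (within the scatter) shows that adding a chloro to the aryl group leaves the read-out essentially where it was. For the measured compounds named here, compound 2 stands on no number at all in this assay: its read-out was not determined, so no step from it can be stated.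

Compound 4 `NC1=NC2(CCOCC2)N(OCCCOc2cccc(Cl)c2Cl)C(N)=N1` is the unmeasured compound. The change from compound 2 to compound 4 is 2,3-dichlorophenyl in place of 3,4-dichlorophenyl on an oxygen on a saturated carbon, the atoms being the same and only the arrangement on the aromatic ring differing. Going by the values given here, no measured step covers this kind of rearrangement, and none compares the oxygen-bearing core directly with the thioether-bearing one. Among the compounds with values here, the only usable anchor is compound 3, which carries the same 2,3-dichlorophenyl group on the thioether-bearing core and gives 89.8%. On that basis compound 4 is expected to sit at a similarly high read-out, estimated at 85% with a range of 65% to 96%.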

Compound 4, a percentage reported as inhibition, at one concentration (the size of the read-out at that concentration, not a potency): 89.8%
The estimate for compound 4 lay 4.8 percentage points below the measured number, and the stated range covers the measured number.
By their numbers in this assay, from the lowest: compounds 1, 3 and 4 (each within the scatter of the next).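

For the compounds shown here, compound 2 gives no number in this assay, so no step to compound 4 can be read. On these data alone, whether 2,3-dichlorophenyl and 3,4-dichlorophenyl give different read-outs on the core of compound 4 stays open. No available evidence bears on this result.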